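The source may hold more compounds than are shown below. What is called first, only, known or untested is meant among the compounds shown, and "the series" means these compounds.

Compound 1 `C=C[C@]1(C)C[C@@H](OC(=O)CNC(=O)NC(=O)c2ccc(Br)cc2)[C@]2(C)[C@H](C)CC[C@]3(CCC(=O)[C@H]32)[C@@H](C)[C@@H]1O`: > 10000 nM
Compound 2 `C=C[C@]1(C)C[C@@H](OC(=O)CNC(=O)NC(=O)c2cccc(F)c2)[C@]2(C)[C@H](C)CC[C@]3(CCC(=O)[C@H]32)[C@@H](C)[C@@H]1O`: > 10000 nM
Compound 3 `C=C[C@]1(C)C[C@@H](OC(=O)CNC(=O)Nc2ccc(F)cc2F)[C@]2(C)[C@H](C)CC[C@]3(CCC(=O)[C@H]32)[C@@H](C)[C@@H]1O`: > 10000 nM

These results come from a functional assay on MCF7 cells (Homo sapiens) for inhibition, read by MTT assay, with a stated time of 72 h (a higher number here means a weaker inhibitor, a lower number a stronger inhibitor), and each one is a limit, not a number. In this assay compound 3 gives > 10000 nM, which is a limit. It shares that position with the others, as the data show (the limit of > 10000 nM in this assay, at which 3 of the 3 values shown sit).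

Compound 4 `C=C[C@]1(C)C[C@@H](OC(=O)CNC(=O)Nc2ccc(F)cc2)[C@]2(C)[C@H](C)CC[C@]3(CCC(=O)[C@H]32)[C@@H](C)[C@@H]1O` has hydrogen in place of fluoro on an aromatic carbon. Among the compounds with values here, two measured steps bear on this change: a step that the two limits leave unreadable from compound 1 to compound 3 and a step that the two limits leave unreadable from compound 2 to compound 3. Neither has a readable size, so no step beyond the scatter is expected in this assay, and no direction can be expected either. The expected step is a step that the limit leaves unreadable from compound 3 to compound 4. For compound 4 the estimate is 15000 nM, with an expected range from 7000 nM to 40000 nM.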

Compound 4, half-maximal inhibitory concentration: > 10000 nM
Compound 4 was reported as a limit (the forecaster's own chance of this, stated with the estimate: 85%); the middle value lies beyond the limit too.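

In this assay compound 4 gives > 10000 nM, which is a limit, so no step between compound 1, compound 2, compound 3 and compound 4 can be read: the limit of > 10000 nM in this assay, at which 4 of the 4 values shown sit.

The compounds shown leave open how strongly each one inhibits, and whether any of these changes makes a difference.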